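Replacing the Aminopropoxy Chain with a Fluoropyridyl Ring

The source may hold more compounds than are shown below. What is called first, only, known or untested is meant among the compounds shown, and "the series" means these compounds.

Among the compounds measured so far, compound 3 `COc1cc(OC)c2c(=O)cc(-c3ccc(OCCCN)cc3)oc2c1` stands highest in a functional assay (Homo sapiens) for antiproliferative activity, read by resazurin assay, with a stated time of 48 h, tested at 10 uM; a higher number here means a stronger effect of the compound at the concentration tested, a lower number a weaker effect: compound 3 gives 39%. Its nearest neighbour is compound 2 `COc1cc(OC)c2c(=O)cc(-c3ccc(OCCN4CCCC4=O)cc3)oc2c1`, which gives 14%, a gap beyond the scatter. Compound 1 `COc1cc(OC)c2c(=O)cc(-c3ccc(OCCBr)cc3)oc2c1` is reported in this assay as "not active" (no number reported), with no number attached. Among the measured compounds shown here, the single one-place step recorded, a number 25 percentage points higher from compound 2 to compound 3 (beyond the scatter), is a modest rise obtained when aminomethyl replaced 2-oxopyrrolidin-1-yl on a saturated chain carbon, two bonds along the chain from an oxygen on an aromatic ring.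

Compound 4 `COc1cc(OC)c2c(=O)cc(-c3ccc(-c4ccc(F)nc4)cc3)oc2c1` takes a different route: 6-fluoropyridin-3-yl in place of 3-aminopropoxy on an aromatic carbon. The whole 3-aminopropoxy chain, including the group whose introduction gave the only rise seen, is removed, and a 6-fluoropyridin-3-yl ring takes its place on the aromatic carbon. For the measured compounds named here, no measured step bears directly on this exchange. What the data show is that the two compounds without an amine on that chain, compound 1 and compound 2, sit at the low end, so a drop is expected; the step from compound 3 is estimated at a number 19 percentage points lower from compound 3 to compound 4 (beyond the scatter). Compound 4 is therefore expected to give about 20%, within a range from 0% to 45%.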

Compound 4, a percentage reported as inhibition, at one concentration (the size of the read-out at that concentration, not a potency): 6%
Compound 4: middle estimate off by 14 percentage points, on the high side; the range from low to high includes it.
By their numbers in this assay, from the lowest: compounds 4 and 2 (each within the scatter of the next); then compound 3.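

In this assay, among the compounds shown here, the exchange on the aromatic carbon, para to a large group, gives a number 33 percentage points lower from compound 3 to compound 4 (beyond the scatter), so the first change to reach beyond the chain end shows that the level of compound 3 does not survive when an aromatic ring stands directly in place of the whole 3-aminopropoxy chain. The second comparison gives a number 8 percentage points lower from compound 2 to compound 4 (within the scatter), which means that the 6-fluoropyridin-3-yl ring and the 2-(2-oxopyrrolidin-1-yl)ethoxy chain cannot be told apart at this position, and that two very different groups without a primary amine end up at the same low level in this read-out. Nothing available explains why the number falls with this exchange.

The compounds shown leave open whether the amine itself or the ether-linked chain carrying it matters more, a question that a 3-aminopropyl chain without the ether oxygen or a 2-aminoethoxy chain would speak to. They also leave open whether an aminomethyl group on the pyridine ring, in place of the fluorine, would lift the number of compound 4.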